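The source may hold more compounds than are shown below. What is called first, only, known or untested is meant among the compounds shown, and "the series" means these compounds.

Compound 1, with the structure `CC1=C(C(=O)OCC(C)C)C(c2ccsc2)NC(=S)N1`, is tested in an assay on membranes from HEK293 cells for displacement of a labelled ligand from adenosine receptor A2b (Homo sapiens), read by scintillation counting, with a stated time of 30 min, tested at 1 uM (a higher number here means more inhibition at the concentration tested (going by the name of the read-out), a lower number less inhibition), and compound 1 gives 15%. Compound 2, with the structure `CC1=C(C(=O)OC(C)(C)C)C(c2ccsc2)NC(=S)N1`, differs from it only by tert-butyl in place of isobutyl on an oxygen next to a carbonyl group; in this assay compound 2 gives 26%. This change produced a number 11 percentage points higher from compound 1 to compound 2 (beyond the scatter).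

Compound 3, with the structure `CC1=C(C(=O)OCC(C)C)C(c2ccco2)NC(=O)N1C`, is built on a different core; the difference between the two cores is not broken down here. In this assay compound 3 gives 4%, the lowest of the three measured numbers.

Compound 4, with the structure `CC1=C(C(=O)OC(C)(C)C)C(c2ccco2)NC(=O)N1C`, has not yet been measured. It carries the same change as the earlier pair, namely (tert-butyl in place of isobutyl on an oxygen next to a carbonyl group), at the same place in the molecule. The step expected from this change is a number 11 percentage points higher from compound 3 to compound 4 (beyond the scatter), set beside the earlier one because on the other core the same change gave a number 11 percentage points higher from compound 1 to compound 2 (beyond the scatter). Compound 4 is therefore estimated to give 15% in this assay. Among the measured compounds shown here, the range of this estimate for compound 4 runs from 2% to 30%, since a single pair is the only guide available.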

Compound 4, a percentage reported as inhibition, at one concentration (the size of the read-out at that concentration, not a potency): 26%
Compound 4: middle estimate off by 11 percentage points, on the low side; measured number inside the range.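

On the core of compound 3, tert-butyl in place of isobutyl on an oxygen next to a carbonyl group gave, in this assay, a number 22 percentage points higher from compound 3 to compound 4 (beyond the scatter), so the change raised the number on both cores. The two steps cannot be told apart in size: the same change on two cores in this assay, a number 11 percentage points higher (beyond the scatter) from compound 1 to compound 2 and a number 22 percentage points higher (beyond the scatter) from compound 3 to compound 4, 11 percentage points apart, within the scatter of two such steps

For these two pairs, then, the step carried from one core to the other in direction and, within the scatter, in size, but two pairs do not show that it would carry to any further core, and readings at a single concentration give no potency and no reason for the step.

The compounds shown leave open how a longer chain, such as n-hexyl, or a benzyl group on the same oxygen would read. They also leave open what a carboxylic acid or an amide in place of the ester would do on either core.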